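Bile acid receptor series: substituent change on the biaryl

The source may hold more compounds than are shown below. What is called first, only, known or untested is meant among the compounds shown, and "the series" means these compounds.

Measured compounds:
compound 1 `COC(=O)/C=C/c1cccc(N(Cc2ccc(/C=C/c3c(C)cc(C)cc3C)cc2)C(=O)C(C)C)c1`: 149 nM
compound 2 `COC(=O)/C=C/c1cccc(N(Cc2ccc(/C=C/c3scnc3C)cc2)C(=O)C(C)C)c1`: 228 nM
compound 3 `COC(=O)/C=C/c1cccc(N(Cc2ccc(-c3cccc(C)c3)cc2)C(=O)C(C)C)c1`: 163 nM

In an assay on isolated protein with Bile acid receptor (Homo sapiens) as the target (on this read-out lower numbers stand for an effect already at smaller amounts and higher numbers for an effect only at larger amounts of compound), compound 3 gives 163 nM, the second highest of the three numbers, with compound 1 nearest and compound 2 furthest; all three values sit within the scatter of one another. The steps of a 1.1-fold higher number from compound 1 to compound 3 (0.04 log units; within the scatter) and a 1.4-fold lower number from compound 2 to compound 3 (0.15 log units; within the scatter) show that swapping the ethenyl-linked groups for 3-methylphenyl moved nothing beyond the scatter. Compound 4 `COC(=O)/C=C/c1cccc(N(Cc2ccc(-c3cc(Cl)ccc3OC)cc2)C(=O)C(C)C)c1` carries 5-chloro-2-methoxyphenyl in place of 3-methylphenyl on an aromatic carbon. Going by the values given here, no measured step changes the substituents on this phenyl, so the only guide is the flat response seen across compounds 1, 2 and 3. The step of a 1.2-fold higher number from compound 3 to compound 4 (0.09 log units; within the scatter) is therefore expected to stay within the scatter. Compound 4 is estimated at 200 nM, range 80 nM to 500 nM.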

Compound 4, half-maximal effective concentration: 226 nM
Compound 4: middle estimate off by 1.1-fold (0.05 log units), on the low side; low and high end bracket the measured number.
By their numbers in this assay, from the lowest: compounds 1, 3, 4 and 2 (each within the scatter of the next).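

In this assay, 5-chloro-2-methoxyphenyl in place of 3-methylphenyl gives a 1.4-fold higher number from compound 3 to compound 4 (0.14 log units; within the scatter) and so adds a hydrogen-bond acceptor on this group without a step beyond the scatter. Set against the ethenyl-linked groups, the same group gives a 1.0-fold lower number from compound 2 to compound 4 (0.00 log units; within the scatter) and a 1.5-fold higher number from compound 1 to compound 4 (0.18 log units; within the scatter), so directly bonded and ethenyl-linked groups at this aromatic carbon remain within the scatter of one another. From the compounds shown here alone, whether an amine or a carboxylic acid on this phenyl would produce a step beyond the scatter remains open. No measurement shown here bears on why these steps stay so small.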